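Three-ring core: a trimethoxyphenyl swap on compound 1

This account rests on a few compounds, and the source may have more. Where it says the series, first, only, none or still open, it means among the compounds named here.

Compound 1 `Cc1cc(O)c(C2=NN(c3ccc(S(N)(=O)=O)cc3)C(c3ccccc3O)C2)cc1Cl` carries a 2-hydroxyphenyl on a saturated ring carbon of its core. In a functional assay on RPMI-8226 cells (Homo sapiens) for antiproliferative activity, with a stated time of 48 h (on this read-out lower numbers stand for higher toxicity in this test and higher numbers for lower toxicity in this test), compound 1 gives > 100000 nM, a limit of the assay rather than a number. Compound 2 `Cc1cc(O)c(C2=NN(c3ccc(S(N)(=O)=O)cc3)C(/C=C/c3ccccc3)C2)cc1Cl` gives 575 nM, so the step of an at least 170-fold lower number from compound 1 to compound 2 (2.24 log units; beyond the scatter). Compound 3 `COc1ccc(C2CC(c3cc(Cl)c(C)cc3O)=NN2c2ccc(S(N)(=O)=O)cc2)cc1OC` gives > 100000 nM, again only a limit. Accordingly the step of an at least 170-fold higher number from compound 2 to compound 3 (2.24 log units; beyond the scatter), while the step that the two limits leave unreadable from compound 1 to compound 3. Compound 4 `COc1ccc(C2CC(c3cc(Cl)c(C)cc3O)=NN2c2ccc(S(N)(=O)=O)cc2)c(OC)c1OC` differs from compound 1 in one place: 2,3,4-trimethoxyphenyl in place of 2-hydroxyphenyl on a saturated ring carbon. Going by the values given here, of the measured steps, the one to compound 3 resembles it most, as a methoxy-bearing phenyl entering at the same position, and that compound sits at the limit of > 100000 nM in this assay, at which 2 of the 3 values shown sit. For compound 4 the expected result in this assay is therefore 150000 nM, between 30000 nM and 600000 nM, with most likely only a limit again; the estimated step is a step that the limit leaves unreadable from compound 1 to compound 4.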

Compound 4, concentration lethal to 50% of the cells: > 100000 nM
Compound 4 ended at the assay's limit; the forecaster's own chance of this, stated with the estimate: 75%; the middle value lies beyond the limit too.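

A third methoxy group, the change from compound 3 to compound 4, still yields no readable number in this assay, and the steps among compound 1, compound 3 and compound 4 cannot be read. Putting 2,3,4-trimethoxyphenyl in place of 2-phenylethenyl gives an at least 170-fold higher number from compound 2 to compound 4 (2.24 log units; beyond the scatter). Among the compounds shown, only compound 2 gives a number rather than a limit: the limit of > 100000 nM in this assay, at which 3 of the 4 values shown sit.

Going by these compounds, whether the double bond of compound 2 matters stays open, as a saturated 2-phenylethyl group would test. Also open, on these data alone, is whether an amine on the phenyl ring would bring a readable number.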